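The compounds below may be only part of what the source reports. "The series", "measured", "known", "first", "only" and "open" are said of these compounds alone.

Going by the values given here, in a functional assay on SK-BR-3 cells (Homo sapiens) for cytotoxicity, read by CellTiter-Glo, with a stated time of 72 h (a higher number here means a weaker inhibitor, a lower number a stronger inhibitor), only two compounds have numbers so far. Compound 1 (`CO[C@H]1C[C@H](C)CC2=C(N3CCC3)C(=O)C=C(NC(=O)/C(C)=C/C=C\[C@H](OC)[C@@H](OC(N)=O)/C(C)=C/[C@H](C)/C1=N\O)C2=O`) gives 310 nM and compound 2 (`C=CCNC1=C2C[C@@H](C)C[C@H](OC)C(=O)[C@@H](C)/C=C(\C)[C@H](OC(N)=O)[C@@H](OC)/C=C\C=C(/C)C(=O)NC(=CC1=O)C2=O`) gives 450 nM and these two numbers lie within the usual scatter of each other, so neither can be ranked above the other. Compound 3 (`CO[C@H]1C[C@H](C)CC2=C(NCCN(C)C)C(=O)C=C(NC(=O)/C(C)=C/C=C\[C@H](OC)[C@@H](OC(N)=O)/C(C)=C/[C@H](C)C1=O)C2=O`) differs from compound 2 in one place ((dimethylamino)methyl in place of vinyl on a saturated chain carbon bound to an amine nitrogen) with (dimethylamino)methyl in place of vinyl on a saturated chain carbon bound to an amine nitrogen. Read one bond further out, allylamino becomes (2-(dimethylamino)ethyl)amino. Among the compounds with values here, no two measured compounds differ in one place only, so this change has no direct precedent here. Within the data shown here, the only guide is compound 2 itself at 450 nM and so no step beyond the scatter is expected in this assay for this change. For compound 3 the estimate is 350 nM with a range from 120 nM to 1000 nM expected.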

Compound 3, half-maximal inhibitory concentration: 100 nM
Beside the measured number, compound 3's estimate is 3.5-fold (0.54 log units) above it, and the stated range ends above it.
By their numbers in this assay, from the lowest: compound 3; then compounds 1 and 2 (each within the scatter of the next).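

In this assay, going by these compounds alone, replacing allylamino with (2-(dimethylamino)ethyl)amino gives a 4.5-fold lower number from compound 2 to compound 3 (0.65 log units; beyond the scatter), which lies beyond the scatter and is the first step in this set that can be read as a real difference. The group on this amine nitrogen therefore affects the result: (dimethylamino)methyl in place of vinyl on a saturated chain carbon gives a stronger inhibitor. Nothing shown here accounts for this gain.

Going by these compounds, it remains open whether the gain needs the dimethylamino nitrogen or only a longer chain, a question that a plain butyl group, with carbon in place of that nitrogen, could address. Also open, on these data alone, is how a longer chain ending in dimethylamino, or a morpholine or a primary amine at the chain end, would compare.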